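Working notes on three measured anilides and a fourth

A few compounds are considered here, and "the series" means these few. Any claim that something is new, unique, unknown or untested is made for them only; others in the source may bear on it.

Measured so far:
compound 1 `O=C(CN1C(=O)C(=O)c2cc(Br)cc(Br)c21)Nc1ccc([N+](=O)[O-])cc1`: 38100 nM
compound 2 `Cc1ccc(NC(=O)CN2C(=O)C(=O)c3cc(Br)cc(Br)c32)cc1`: 25000 nM
compound 3 `O=C(CN1C(=O)C(=O)c2cc(Br)cc(Br)c21)Nc1ccccc1[N+](=O)[O-]`: 26000 nM

In an ADME assay on Vero cells (Chlorocebus sabaeus) for cytotoxicity, read by XTT assay, with a stated time of 72 h (a lower number here means a stronger inhibitor, a higher number a weaker inhibitor), compound 1 gives 38100 nM, compound 2 gives 25000 nM and compound 3 gives 26000 nM. Compound 2 differs from compound 1 by methyl in place of nitro on an aromatic carbon; in this assay this gave a 1.5-fold lower number from compound 1 to compound 2 (0.18 log units; within the scatter). Compound 3 has the same atoms as compound 1 joined differently; the difference between the two cores is not broken down here, and their values in this assay lie within the scatter of each other.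

Compound 4 `Cc1ccccc1NC(=O)CN1C(=O)C(=O)c2cc(Br)cc(Br)c21` is not yet measured. It differs from compound 3 by methyl in place of nitro on an aromatic carbon. The place is not the same as in the earlier pair: there the methyl enters para to a large group, here ortho to a large group, so this is the same kind of change, not the same. Because the step of a 1.5-fold lower number from compound 1 to compound 2 (0.18 log units; within the scatter) stayed within the scatter, a step of about a 1.2-fold lower number from compound 3 to compound 4 (0.07 log units; within the scatter) is expected for compound 4 in this assay. Compound 4 is estimated at 22000 nM, expected between 10000 nM and 48000 nM.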

Compound 4, half-maximal inhibitory concentration: 29900 nM
Estimate against measurement, compound 4: 1.4-fold (0.13 log units) below; measured number inside the range.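

In this assay, methyl in place of nitro on an aromatic carbon gives a 1.2-fold higher number from compound 3 to compound 4 (0.06 log units; within the scatter), and 2-methylphenyl in place of 4-methylphenyl on an amide-type nitrogen gives a 1.2-fold higher number from compound 2 to compound 4 (0.08 log units; within the scatter). Set beside the earlier step, the change shows no difference that can be told apart between the core of compound 1 and the core of compound 3: the same change on two cores in this assay, a 1.5-fold lower number (0.18 log units; within the scatter) from compound 1 to compound 2 and a 1.2-fold higher number (0.06 log units; within the scatter) from compound 3 to compound 4, 1.8-fold (0.24 log units) apart, within the scatter of two such steps. Among these compounds, this shows only that the change stayed small in both pairs; it does not fix a direction or size for the step, and two pairs do not establish that it carries to other cores.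

As far as these compounds go, whether an amine or a carboxylic acid in place of methyl on an aromatic carbon would give a step beyond the scatter in this assay stays open. The same holds for a longer chain on the amide-type nitrogen.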